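Cyclohexyl in Place of Pyridin-4-yl: an Expected Shift

The compounds below may be only part of what the source reports. "The series", "measured", "known", "first", "only" and "open" are said of these compounds alone.

Three analogues sharing one core have been measured in an assay on Cortex for displacement of a labelled ligand from adenosine receptor A1 (Rattus norvegicus); on this read-out higher numbers stand for weaker inhibition and lower numbers for stronger inhibition. Compound 1 `CCCn1c(=O)c2nc(-c3ccccc3)[nH]c2n(C)c1=O` gives 6.96 nM, compound 2 `CCCn1c(=O)c2nc(-c3ccc(O)cc3)[nH]c2n(C)c1=O` gives 1.28 nM, and compound 3 `CCCn1c(=O)c2nc(-c3ccncc3)[nH]c2n(C)c1=O` gives 27.6 nM. Compound 3 thus stands highest of the three, with a 4.0-fold higher number from compound 1 to compound 3 (0.60 log units; beyond the scatter) and a 22-fold higher number from compound 2 to compound 3 (1.33 log units; beyond the scatter); the step of a 5.4-fold lower number from compound 1 to compound 2 (0.74 log units; beyond the scatter) separates the other two. Compound 4 `CCCn1c(=O)c2nc(C3CCCCC3)[nH]c2n(C)c1=O` carries cyclohexyl in place of pyridin-4-yl on an aromatic carbon. For the measured compounds named here, no measured step covers a cyclohexyl group; the nearest, a 4.0-fold higher number from compound 1 to compound 3 (0.60 log units; beyond the scatter), shows that the pyridin-4-yl of compound 3 went with a higher number than the phenyl of compound 1, and compound 4, like compound 1, has no hydrogen-bond acceptor in that ring. A modest downward step is therefore expected, a 5.5-fold lower number from compound 3 to compound 4 (0.74 log units; beyond the scatter). Compound 4 is estimated at 5 nM, within 1 nM to 30 nM.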

Compound 4, inhibition constant: 5.02 nM
The estimate for compound 4 lay 1.0-fold (0.00 log units) below the measured number; the range from low to high includes it.
By their numbers in this assay, from the lowest: compound 2; then compounds 4 and 1 (each within the scatter of the next); then compound 3.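

At this position, on an aromatic carbon between two ring nitrogen atoms, the ring need not be aromatic: cyclohexyl and phenyl stay within the scatter of each other (a 1.4-fold lower number from compound 1 to compound 4 (0.14 log units; within the scatter)). Cyclohexyl also parts from pyridin-4-yl (a 5.5-fold lower number from compound 3 to compound 4 (0.74 log units; beyond the scatter)) but does not reach the number of the 4-hydroxyphenyl group (a 3.9-fold higher number from compound 2 to compound 4 (0.59 log units; beyond the scatter)). No measurement offered here gives a reason for these steps. Going by these compounds, what remains open is how a hydroxy group or an amine on the cyclohexyl ring would compare with compound 4, and whether cyclopentyl or an open butyl chain would do the same.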